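Phenoxy chain shortening in a thiazole-acid prostanoid series

This account rests on a few compounds, and the source may have more. Where it says the series, first, only, none or still open, it means among the compounds named here.

Measured so far in a functional assay on Chem1 cells for agonist activity at prostaglandin F2-alpha receptor (Homo sapiens), read by fluorescence and calcium flux; a higher number here means that more compound is needed for the effect, a lower number that less compound is needed:
compound 1 `O=C(O)c1csc([C@H]2CC[C@@H]3[C@@H](/C=C/CCCOc4ccccc4)[C@H](O)C[C@@H]3O2)n1` gives 8500 nM.
compound 2 `O=C(O)c1csc([C@H]2CC[C@@H]3[C@@H](/C=C/CCOc4ccccc4)[C@H](O)C[C@@H]3O2)n1` gives 380 nM.
compound 3 `O=C(O)c1csc([C@H]2CC[C@@H]3[C@@H](CCCOc4ccccc4)[C@H](O)C[C@@H]3O2)n1` gives only a limit of this assay, > 10000 nM.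

Compound 1 and compound 2 differ by phenoxy in place of phenoxymethyl on a saturated chain carbon, two bonds along the chain from a double-bonded chain carbon. That step reads a 22-fold lower number from compound 1 to compound 2 (1.35 log units; beyond the scatter), a gain that lies well beyond the scatter.

Compound 4 `O=C(O)c1csc([C@H]2CC[C@@H]3[C@@H](CCOc4ccccc4)[C@H](O)C[C@@H]3O2)n1` is not yet measured. It differs from compound 3 by phenoxy in place of phenoxymethyl on a saturated chain carbon, two bonds along the chain from a saturated ring carbon. The place lines are not identical: in the earlier pair the chain carbon sits two bonds from a double-bonded chain carbon, here two bonds from a saturated ring carbon, so this is the same kind of change rather than the same one. How the core of compound 3 differs from that of compound 1 is not broken down here.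

On these data alone, compound 3 sits at the limit of > 10000 nM in this assay, at which 1 of the 3 values shown sits, so its starting point is unknown beyond that limit. A step of the earlier kind applied from compound 3 is expected to give compound 4 a gain of about an at least 4.0-fold lower number from compound 3 to compound 4 (0.60 log units; beyond the scatter). Compound 4 is therefore expected to fall near 2500 nM, within 500 nM to 10000 nM, with a real chance that only a limit is returned.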

Compound 4, half-maximal effective concentration: > 10000 nM
Compound 4 was reported as a limit; the forecaster's own chance of this, stated with the estimate: 35%; middle value at least 4.0-fold (0.60 log units) away from the limit.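

Compound 3 and compound 4 each return only a limit in this assay, so no step can be read between them: the limit of > 10000 nM in this assay, at which 2 of the 4 values shown sit.

The compounds shown leave open how far either compound lies past that limit, and whether phenoxy in place of phenoxymethyl has any effect on this chain, as it does between compound 1 and compound 2.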